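Straight Chain for Branched Chain at the Amine Nitrogen

The compounds below may be only part of what the source reports. "The series", "measured", "known", "first", "only" and "open" are said of these compounds alone.

Three compounds were measured in a functional assay for inhibition, read by spectrophotometry, with a stated time of 30 min, tested at 1 uM; on this read-out lower numbers stand for less inhibition and higher numbers for more inhibition at the one concentration tested (going by the name of the read-out). Compound 1 `COc1cc(/C=C/C(=O)/C=C(/C=C/c2ccc(OC(C)=O)c(OC)c2)NC2CCCCC2)ccc1OC(C)=O` gives 0.01%, compound 2 `CCC(C)NC(=C\C(=O)/C=C/c1ccc(O)c(OC)c1)/C=C/c1ccc(O)c(OC)c1` gives 0.13%, and compound 3 `CC(=O)Oc1ccc(/C=C/C(=O)/C=C(/C=C/c2ccc(OC(C)=O)cc2)NCC(C)C)cc1` gives 0%. Compound 2 holds the highest of the three numbers, yet its gaps to compound 1 and to compound 3 both lie within the scatter, so none of the three can be set apart. Compound 4 `CCCCNC(=C\C(=O)/C=C/c1ccc(O)c(OC)c1)/C=C/c1ccc(O)c(OC)c1` has the same atoms as compound 2, joined differently: butyl in place of sec-butyl on an amine nitrogen. Because compound 2 gives 0.13% and the other two give numbers within the scatter of it in this assay, no step beyond the scatter is expected. The step of a number 0 percentage points lower from compound 2 to compound 4 (within the scatter) is estimated as essentially none. Compound 4 is estimated at 0.1% in this assay, within 0% to 5%.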

Compound 4, a percentage reported as inhibition, at one concentration (the size of the read-out at that concentration, not a potency): 0.08%
For compound 4 the middle estimate is 0 percentage points above the measured one, within the range that was stated.
By their numbers in this assay, from the lowest: compounds 3, 1, 4 and 2 (each within the scatter of the next).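

Butyl in place of sec-butyl on the amine nitrogen gives a number 0.1 percentage points lower from compound 2 to compound 4 (within the scatter) in this assay, the first comparison here of two compounds that differ in one place. At the one concentration tested, rearranging these four carbons from a branched to a straight chain therefore leaves no readable mark on the result. Nothing measured here offers an explanation for this result. Still open, from the compounds shown here alone, is whether a longer chain, such as octyl, or a carboxylic acid at the end of the chain would read differently at this nitrogen.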